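Replacing a phenyl-bearing diene with a pyrrole ring

This account rests on a few compounds, and the source may have more. Where it says the series, first, only, none or still open, it means among the compounds named here.

Compound 2 `Cc1ccc(S(=O)(=O)NC(=O)Nc2ccccc2C(=O)/C=C/C=C/c2ccccc2)cc1` carries a 4-phenylbuta-1,3-dien-1-yl chain on the shared core. Among the measured compounds shown here, in an ADME assay on the whole organism for cytotoxicity, with Artemia salina as the target, with a stated time of 24 h (on this read-out lower numbers stand for an effect already at smaller amounts and higher numbers for an effect only at larger amounts of compound), compound 2 gives 18.2 ug/mL, the lowest of the two numbers measured so far. For the measured compounds named here, its only measured neighbour is compound 1 `Cc1ccc(S(=O)(=O)NC(=O)Nc2ccccc2C(=O)/C=C/c2ccccc2[N+](=O)[O-])cc1`, which in this assay gives 40.1 ug/mL; the exchange of 2-nitrophenyl for 2-phenylethenyl at the same place brought a 2.2-fold lower number from compound 1 to compound 2 (0.34 log units; beyond the scatter).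

Compound 3 `Cc1ccc(S(=O)(=O)NC(=O)Nc2ccccc2C(=O)/C=C/c2ccc[nH]2)cc1` differs from compound 2 in one place: 1H-pyrrol-2-yl in place of 2-phenylethenyl on a double-bonded chain carbon bound to a double-bonded chain carbon. Going by the values given here, none of the measured steps involves a 1H-pyrrol-2-yl group, so the one step from compound 1 to compound 2 bears on it only loosely: it shows that exchanging the group at this position moved the read-out by a modest amount. Compound 3 returns to an aryl ring directly on the chain, as in compound 1, whose number was higher. The expectation for compound 3 is therefore a small rise at most, a 1.5-fold higher number from compound 2 to compound 3 (0.19 log units; within the scatter), quite possibly remaining within the scatter. Compound 3 is estimated at 28 ug/mL, within 12 ug/mL to 70 ug/mL.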

Compound 3, concentration for half-maximal effect: 32.1 ug/mL
Estimate against measurement, compound 3: 1.1-fold (0.06 log units) below; measured number inside the range.
By their numbers in this assay, from the lowest: compounds 2, 3 and 1 (each within the scatter of the next, the first and the last beyond it).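

In this assay, the pyrrole on the chain does not separate from either neighbour: the exchange for the longer chain leaves the number within the scatter (a 1.8-fold higher number from compound 2 to compound 3 (0.25 log units; within the scatter)), and so does the exchange for the nitro-bearing ring (a 1.2-fold lower number from compound 1 to compound 3 (0.10 log units; within the scatter)). Compound 3 therefore sits within the scatter of two compounds that are themselves printed as beyond it from each other, so the read-out gives this one-place change no clear direction, even though the entering group brings a five-membered aromatic ring with one hetero atom and a hydrogen-bond donor in place of a larger all-carbon group. No measurement offered here explains these numbers or ties them to any feature of the groups.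

From the compounds shown here alone, what remains open is whether the hydrogen on the pyrrole nitrogen plays any part in the number, which a 1-methyl-1H-pyrrol-2-yl group or a furan-2-yl ring at the same place could test. Going by these compounds, it is also open whether a clearly different group on this chain carbon, such as an amine, a carboxylic acid or a longer chain, would move the number beyond the scatter.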